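The source may report more compounds than this note shows. Statements on the series, on what has been measured and on what is new or still open speak of the compounds shown alone.

Measured in a functional assay on MCF7 cells (Homo sapiens) for inhibition, with a stated time of 48 h; on this read-out higher numbers stand for weaker inhibition and lower numbers for stronger inhibition:

- compound 1 `COc1cc(Sc2c[nH]c3ccc([N+](=O)[O-])cc23)cc(OC)c1OC` gives 560 nM
- compound 2 `COc1ccc2[nH]c(C)c(Sc3cc(OC)c(OC)c(OC)c3)c2c1` gives 18 nM

Of these two, compound 1 stands at the higher number and is therefore the weaker inhibitor, and its gap to compound 2 lies beyond the usual scatter. The two differ in more than one place, so that gap cannot be assigned to any single group.

The next compound, compound 3 `COc1cc(Sc2c[nH]c3ccc(OCCO)cc23)cc(OC)c1OC`, keeps the core of compound 1 and changes one group: 2-hydroxyethoxy in place of nitro on an aromatic carbon. Among the measured compounds shown here, no measured pair isolates this change, so the data give no direct step for it. For the measured compounds named here, the only loose guide is compound 2, which also carries no nitro and reaches 18 nM in this assay. On that basis, an estimated step (a 3.7-fold lower number from compound 1 to compound 3 (0.57 log units; beyond the scatter)) toward stronger inhibition is expected, beyond the scatter but smaller than the gap between the two measured compounds. For compound 3 the expected value is 150 nM, with an estimated range from 30 nM to 700 nM.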

Compound 3, half-maximal inhibitory concentration: 95 nM
Compound 3: middle estimate off by 1.6-fold (0.20 log units), on the high side; the range from low to high includes it.
By their numbers in this assay, from the lowest: compound 2; then compound 3; then compound 1.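

In this assay, among the compounds shown here, the step taken at this position is a 5.9-fold lower number from compound 1 to compound 3 (0.77 log units; beyond the scatter), and it is the first comparison here in which only one group differs, so this gap, unlike the one between compound 1 and compound 2, can be assigned to a single change. It shows that, on the core of compound 1, this aromatic carbon of the six-membered ring does not need nitro for stronger inhibition, since 2-hydroxyethoxy gives a lower number beyond the usual scatter. The incoming group keeps the count of hydrogen-bond acceptors and adds one hydrogen-bond donor, but nothing available explains why the number falls.

As far as these compounds go, it remains open whether the step comes from losing nitro or from gaining 2-hydroxyethoxy, and whether an amine or a carboxylic acid in place of the hydroxyl, or a longer chain, would hold the number of compound 3 or move it. From the compounds shown here alone, it is also open whether the same change would give a step of similar size on the core of compound 2.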